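This account rests on a few compounds, and the source may have more. Where it says the series, first, only, none or still open, it means among the compounds named here.

Compound 1 `C#CCNC(=O)c1ccc(C(CC)(CC)c2ccc(OCC(O)C(C)(C)C)c(C)c2)n1CC` was tested in a functional assay on HepG2 cells (Homo sapiens), read by MTT assay, with a stated time of 48 h; on this read-out higher numbers stand for weaker inhibition and lower numbers for stronger inhibition. Compound 1 reached only the limit of the assay, > 50000 nM, so no number for it is known, and the limit of > 50000 nM in this assay, at which 1 of the 2 values shown sits, tells what this limit means. Another member of the same series is compound 2 `CCn1c(C(=O)N(C)CC(=O)O)ccc1C(CC)(CC)c1ccc(OCC(=O)C(C)(C)C)c(C)c1`; in this assay compound 2 gives 25200 nM. Compound 3 `CCn1c(C(=O)Oc2ccc(CCO)cc2)ccc1C(CC)(CC)c1ccc(OCC(O)C(C)(C)C)c(C)c1` comes from compound 1 by a single change: a group of 10 heavy atoms (8 carbon, 2 oxygen; one six-membered aromatic ring of carbon only) in place of a group of 4 heavy atoms (3 carbon, 1 nitrogen; no ring), on a carbonyl carbon. Going by the values given here, no measured pair shows this change. For compound 3 the expected result in this assay is 40000 nM, within 12000 nM to 150000 nM. The step expected is an at least 1.2-fold lower number from compound 1 to compound 3 (0.09 log units; that floor lies within the scatter), and a further limit instead of a number remains quite possible.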

Compound 3, half-maximal inhibitory concentration: > 50000 nM
Compound 3: a limit, no number; the forecaster's own chance of this, stated with the estimate: 45%; middle value at least 1.2-fold (0.09 log units) away from the limit.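

Compound 1 and compound 3 both give only a limit in this assay, not a number, so no step can be read between them: the limit of > 50000 nM in this assay, at which 2 of the 3 values shown sit.

On these data alone, whether replacing propargylamino with the group carrying the six-membered aromatic ring changes inhibition at all stays open.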